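Sulfonamide nitrogen variation, compound 3 to compound 4

The source may report more compounds than this note shows. Statements on the series, on what has been measured and on what is new or still open speak of the compounds shown alone.

Measured so far in a functional assay on the whole organism (aorta) with Rattus norvegicus as the target; a lower number here means a smaller maximal response, a higher number a larger maximal response:

- compound 1 `CC(C)NS(=O)(=O)c1ccc2c(c1)C(n1ccccc1=O)=CC(C)(C)O2`: 76.9%
- compound 2 `CC1(C)C=C(n2ccccc2=O)c2cc(S(=O)(=O)Nc3ccccc3)ccc2O1`: 63.6%; 82.5% (2 entries)
- compound 3 `CC1(C)C=C(n2ccccc2=O)c2cc(S(=O)(=O)Nc3ccc(C#N)cc3)ccc2O1`: 84%

All three compounds share the same core and differ only at the sulfonamide nitrogen. For the measured compounds named here, compound 3 carries the 4-cyanophenyl group there; the only single-point step that reaches it is a number 7.1 percentage points higher from compound 1 to compound 3 (within the scatter), so compound 3 and compound 1 cannot be told apart on these numbers. Compound 2, with a plain phenyl on the sulfonamide nitrogen, has two entries in this assay that sit apart from each other (the several entries of compound 2 in this assay, 63.6%; 82.5% (2 entries)), which shows how wide the repeat spread of this measurement can be in this series.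

Compound 4 `CN(c1ccccc1)S(=O)(=O)c1ccc2c(c1)C(n1ccccc1=O)=CC(C)(C)O2` has not been measured. It differs from compound 3 by methyl(phenyl)amino in place of (4-cyanophenyl)amino on a sulfonyl sulfur. The change removes the nitrile and the hydrogen on the sulfonamide nitrogen and adds a methyl there. Going by the values given here, no measured pair covers this exact change; the one measured step, a number 7.1 percentage points higher from compound 1 to compound 3 (within the scatter), was within the scatter, and the phenyl analogue compound 2 gave values that straddle those of compound 1 and compound 3. No step beyond the scatter is therefore expected in this assay in either direction.

Compound 4 is estimated at 76%, with a range of 60% to 90%. The expected step is a number 8 percentage points lower from compound 3 to compound 4 (within the scatter).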

Compound 4, largest response reached (Emax), in percent of the reference or control that the assay uses: 64.2%
Compound 4: middle estimate off by 11.8 percentage points, on the high side; measured number inside the range.
By their numbers in this assay, from the lowest: compound 4; then compounds 1 and 3 (each within the scatter of the next).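

The sulfonamide nitrogen now gives steps beyond the scatter in this assay: there is a number 19.8 percentage points lower from compound 3 to compound 4 (beyond the scatter), and there is a number 12.7 percentage points lower from compound 1 to compound 4 (beyond the scatter). Among compounds 1, 3 and 4, isopropylamino and (4-cyanophenyl)amino could not be separated, with a number 7.1 percentage points higher from compound 1 to compound 3 (within the scatter), whereas methyl(phenyl)amino, the one group of these without a hydrogen on the sulfonamide nitrogen, stands apart from both, though only modestly. The phenyl analogue compound 2, which differs from compound 4 only by that hydrogen in place of the methyl, cannot show what the methyl alone does, because its entries disagree too widely: the several entries of compound 2 in this assay, 63.6%; 82.5% (2 entries)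

Compound 4 differs from compound 3 in both the methyl and the nitrile, so the shown compounds do not assign the lower maximal response to either change alone. From the compounds shown here alone, it also remains open whether dimethylamino on the sulfonyl sulfur, which likewise has no hydrogen on the nitrogen but carries no aromatic ring, would sit with compound 4 or with compounds 1 and 3.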